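A few compounds are considered here, and "the series" means these few. Any claim that something is new, unique, unknown or untested is made for them only; others in the source may bear on it.

Compound 1 `Oc1cccc(-c2cc(-c3ccsc3)cc(-c3ccccc3O)n2)c1` and compound 2 `Oc1ccc(-c2cc(-c3ccsc3)cc(-c3ccccc3O)n2)cc1` share one core, carrying a thiophen-3-yl group and a 2-hydroxyphenyl group, and differ by 4-hydroxyphenyl in place of 3-hydroxyphenyl on an aromatic carbon. In a functional assay on DU-145 cells (Homo sapiens) for cytotoxicity, read by CCK-8 assay (on this read-out higher numbers stand for weaker inhibition and lower numbers for stronger inhibition), compound 1 gives only a limit, > 50000 nM. Compound 2 likewise gives only a limit in this assay, > 50000 nM. The step that the two limits leave unreadable from compound 1 to compound 2 cannot be sized because of the limit of > 50000 nM in this assay, at which 2 of the 3 values shown sit. Compound 3 `Oc1ccc(-c2cc(-c3cccnc3)cc(-c3cccc(O)c3)n2)cc1` rests on a different core, carrying a pyridin-3-yl group and a 4-hydroxyphenyl group; the difference between the two cores is not broken down here. In this assay compound 3 gives 6390 nM. Compound 4 `Oc1ccc(-c2cc(-c3cccnc3)cc(-c3ccc(O)cc3)n2)cc1` differs from compound 3 by 4-hydroxyphenyl in place of 3-hydroxyphenyl on an aromatic carbon, the same kind of change as from compound 1 to compound 2, though here the place is meta to a 4-hydroxyphenyl group and meta to a pyridin-3-yl group rather than meta to a 2-hydroxyphenyl group and meta to a thiophen-3-yl group. The earlier step gives no readable size, so the expected step of a 1.1-fold higher number from compound 3 to compound 4 (0.04 log units; within the scatter) is taken as small, resting on compound 3 at 6390 nM. Compound 4 is estimated at 7000 nM, within 2000 nM to 30000 nM.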

Compound 4, half-maximal inhibitory concentration: 240 nM
Compound 4: the middle estimate sits 29-fold (1.46 log units) above what was measured, and the stated range ends above it.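

In this assay, 4-hydroxyphenyl in place of 3-hydroxyphenyl gives a 27-fold lower number from compound 3 to compound 4 (1.43 log units; beyond the scatter) on the core of compound 3, so on that core the change is large. On the core of compound 1 the same change cannot be read, because compound 1 and compound 2 each give only a limit and not a number: the limit of > 50000 nM in this assay, at which 2 of the 4 values shown sit. One readable step therefore shows no transfer between cores, neither that the gain carries over nor that it fails to.

Open, from the compounds shown here alone, is whether the gain on the core of compound 4 depends on the pyridin-3-yl group. Also open, going by these compounds, is how an amine or a methoxy group would read in place of the hydroxy group of either 4-hydroxyphenyl group.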